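Trifluoromethyl for methyl: expected inhibition of compound 3

This account rests on a few compounds, and the source may have more. Where it says the series, first, only, none or still open, it means among the compounds named here.

Compound 1 `CC(=O)c1ccc(OCc2ccc(C)cc2)cc1` stands lowest of the two numbers in hand. In an assay on isolated protein for inhibition of Amine oxidase [flavin-containing] A (Homo sapiens), read by Amplex Red, with a stated time of 15 min, tested at 100 uM (on this read-out lower numbers stand for less inhibition and higher numbers for more inhibition at the one concentration tested (going by the name of the read-out)), compound 1 gives 5.96%, and compound 2 `CC(=O)c1ccc(OCc2ccccc2[N+](=O)[O-])cc1` gives 34%, a gap beyond the scatter. Compound 3 `CC(=O)c1ccc(OCc2ccc(C(F)(F)F)cc2)cc1` differs from compound 1 by trifluoromethyl in place of methyl on an aromatic carbon. Among the compounds with values here, no step between measured compounds covers this exact change, so the direction rests on the spread between compound 1 and compound 2 alone. A modest rise beyond the scatter is expected, a number 10 percentage points higher from compound 1 to compound 3 (within the scatter) in this assay. Compound 3 is estimated at 16%, with a range from 3% to 35%.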

Compound 3, a percentage reported as inhibition, at one concentration (the size of the read-out at that concentration, not a potency): 26.4%
Compound 3: middle estimate off by 10.4 percentage points, on the low side; measured number inside the range.
By their numbers in this assay, from the lowest: compound 1; then compounds 3 and 2 (each within the scatter of the next).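

In this assay, trifluoromethyl in place of methyl on an aromatic carbon, para to a large group, gives a number 20.4 percentage points higher from compound 1 to compound 3 (beyond the scatter). Within the data shown here, this is the first single-place step, and it shows that the read-out responds to a change at this position. Nothing at hand bears on what lies behind the step.

Going by these compounds, with one pair at this position, how other groups there would read stays open, for example an amine, a carboxylic acid or a longer chain. Potency also stays open, as the read-out comes from a single concentration.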